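From methoxy to nitro in an antiproliferative series

The source may report more compounds than this note shows. Statements on the series, on what has been measured and on what is new or still open speak of the compounds shown alone.

Measured in a functional assay on HT-29 cells (Homo sapiens) for antiproliferative activity, read by MTT assay, with a stated time of 96 h (on this read-out lower numbers stand for stronger inhibition and higher numbers for weaker inhibition), so far:
- Compound 1 `CCc1ccc(N2C(=O)NC3(CSC4=C3C(=O)c3ncccc3C4=O)C2=O)cc1` gives 1 nM
- Compound 2 `COc1ccc(N2C(=O)NC3(CSC4=C3C(=O)c3ncccc3C4=O)C2=O)cc1` gives 2 nM
- Compound 3 `O=C1NC(=O)C2(CSC3=C2C(=O)c2ncccc2C3=O)N1` gives 190 nM; 180 nM; 190 nM (3 entries)

Compound 2 sits at the low end of these numbers, far under compound 3 at 190 nM; 180 nM; 190 nM (3 entries). For the measured compounds named here, the only measured step that reaches it is a 2.0-fold higher number from compound 1 to compound 2 (0.30 log units; within the scatter), so it cannot be told apart from its nearest neighbour.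

The next change leads to compound 4 `O=C1C2=C(C(=O)c3ncccc31)C1(CS2)NC(=O)N(c2ccc([N+](=O)[O-])cc2)C1=O`, with nitro in place of methoxy on an aromatic carbon. Going by the values given here, the one step that bears on this is the ethyl to methoxy exchange, which also changes the group on an aromatic carbon and stayed within the scatter at a 2.0-fold higher number from compound 1 to compound 2 (0.30 log units; within the scatter). As far as these compounds go, on that single step, no shift beyond the scatter is expected in this assay, in either direction, although nitro itself is untested here. The estimated change is a 1.5-fold higher number from compound 2 to compound 4 (0.18 log units; within the scatter). Compound 4 is expected to read about 3 nM, with an estimated range from 1 nM to 12 nM.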

Compound 4, half-maximal inhibitory concentration: 250 nM
Beside the measured number, compound 4's estimate is 83-fold (1.92 log units) below it; the whole stated range lies below it.
By their numbers in this assay, from the lowest: compounds 1 and 2 (each within the scatter of the next); then compound 4.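

The earlier compounds shown here gave the impression that this position accepts an exchange of groups freely, but the change from 4-methoxyphenyl to 4-nitrophenyl in this assay gives a 130-fold higher number from compound 2 to compound 4 (2.10 log units; beyond the scatter) and so shows that the position does respond to what it carries. Set against ethyl, nitro gives a 250-fold higher number from compound 1 to compound 4 (2.40 log units; beyond the scatter) as well, so the loss appears against both groups shown and does not depend on one partner. The gap is far wider than the spread of repeat readings: the several entries of compound 3 in this assay, 190 nM; 180 nM; 190 nM (3 entries).

With only ethyl, methoxy and nitro at this position, the compounds shown do not tell what sets nitro apart from the other two. As far as these compounds go, whether an amine, a nitrile or a chlorine atom in the same place would read like ethyl and methoxy or like nitro remains open.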